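This account rests on a few compounds, and the source may have more. Where it says the series, first, only, none or still open, it means among the compounds named here.

Three compounds share one core and differ only in the amine on the aromatic carbon. Compound 1 `CNc1nc(-c2cc(-c3ccon3)n(Cc3ccccc3F)n2)ncc1F` gives 20 nM in an assay on a protein complex for activation of soluble guanylate cyclase (Homo sapiens), read by cGMP accumulation, in the presence of a further agent that is not named here; on this read-out lower numbers stand for an effect already at smaller amounts and higher numbers for an effect only at larger amounts of compound. Compound 2 `Fc1ccccc1Cn1nc(-c2ncc(F)c(N3CCCC3)n2)cc1-c1ccon1` gives 83 nM in this assay. Compound 3 `OC1CCCN(c2nc(-c3cc(-c4ccon4)n(Cc4ccccc4F)n3)ncc2F)C1` gives 33 nM in this assay. Compound 3 stands second highest of the three numbers, with a 1.7-fold higher number from compound 1 to compound 3 (0.22 log units; within the scatter) and a 2.5-fold lower number from compound 2 to compound 3 (0.40 log units; beyond the scatter); the remaining step is a 4.2-fold higher number from compound 1 to compound 2 (0.62 log units; beyond the scatter). Compound 4 `OCC1CCCCN1c1nc(-c2cc(-c3ccon3)n(Cc3ccccc3F)n2)ncc1F` carries the change (2-(hydroxymethyl)piperidin-1-yl in place of 3-hydroxypiperidin-1-yl on an aromatic carbon). For the measured compounds named here, no measured step exchanges one six-membered non-aromatic ring group for another, and the amine swaps seen so far stay modest, so only a small step is expected, a 1.2-fold higher number from compound 3 to compound 4 (0.08 log units; within the scatter), with no direction beyond the scatter. Compound 4 is estimated at 40 nM, with a range from 15 nM to 110 nM.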

Compound 4, half-maximal effective concentration: 35 nM
Compound 4: the middle estimate sits 1.1-fold (0.06 log units) above what was measured; the range from low to high includes it.
By their numbers in this assay, from the lowest: compounds 1, 3 and 4 (each within the scatter of the next); then compound 2.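

Exchanging 3-hydroxypiperidin-1-yl for 2-(hydroxymethyl)piperidin-1-yl gives a 1.1-fold higher number from compound 3 to compound 4 (0.03 log units; within the scatter) in this assay, so this position tolerates moving the hydroxyl-bearing substituent around the six-membered ring without a readable change. The new group repeats the pattern of 3-hydroxypiperidin-1-yl against the two other amines: a 2.4-fold lower number from compound 2 to compound 4 (0.38 log units; beyond the scatter) and a 1.8-fold higher number from compound 1 to compound 4 (0.24 log units; within the scatter). No evidence on the cause of these steps is at hand.

Whether the hydroxy group itself contributes remains open, since unsubstituted piperidin-1-yl is not among these compounds. From the compounds shown here alone, the effect of 3-hydroxypyrrolidin-1-yl, which would separate ring size from the hydroxy group, is also open.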